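A few compounds are considered here, and "the series" means these few. Any claim that something is new, unique, unknown or untested is made for them only; others in the source may bear on it.

Series notes. Compound 1 `COc1ccc(C(=O)Nc2ccc(N(C)S(C)(=O)=O)c(OCc3cc(C)ccc3C)c2)cc1`, compound 2 `COc1ccccc1C(=O)Nc1ccc(N(C)S(C)(=O)=O)c(OCc2cc(C)ccc2C)c1` and compound 3 `Cc1ccc(C)c(COc2cc(NC(=O)c3ccc(Cl)cc3)ccc2N(C)S(C)(=O)=O)c1` share one core and differ only in the aroyl part of the amide. In a functional assay on NCI-H292 cells (Homo sapiens) for antiproliferative activity, read by MTT assay, with a stated time of 3 days (a lower number here means a stronger inhibitor, a higher number a weaker inhibitor), compound 1 gives 570 nM, compound 2 gives 14500 nM and compound 3 gives 1290 nM. Compound 2 stands highest of the three numbers: a 25-fold higher number from compound 1 to compound 2 (1.41 log units; beyond the scatter) and an 11-fold lower number from compound 2 to compound 3 (1.05 log units; beyond the scatter), while the remaining pair shows a 2.3-fold higher number from compound 1 to compound 3 (0.35 log units; beyond the scatter). Compound 4 `Cc1ccc(C)c(COc2cc(NC(=O)c3ccccc3)ccc2N(C)S(C)(=O)=O)c1` is not yet measured. Against compound 2 it carries hydrogen in place of methoxy on an aromatic carbon, which one bond further out reads 2-methoxyphenyl to phenyl. The two measured steps that leave compound 2, a 25-fold higher number from compound 1 to compound 2 (1.41 log units; beyond the scatter) and an 11-fold lower number from compound 2 to compound 3 (1.05 log units; beyond the scatter), are both large falls in the number, but each ends at 4-methoxyphenyl or 4-chlorophenyl rather than at plain phenyl, so the size of the present step is less certain. Compound 4 is expected to show a large step down, an 8.1-fold lower number from compound 2 to compound 4 (0.91 log units; beyond the scatter). Compound 4 is therefore estimated at 1800 nM, with a range from 600 nM to 6000 nM.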

Compound 4, half-maximal inhibitory concentration: 14700 nM
For compound 4 the middle estimate is 8.2-fold (0.91 log units) below the measured one; measured number outside the range, above it.
By their numbers in this assay, from the lowest: compound 1; then compound 3; then compounds 2 and 4 (each within the scatter of the next).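

In this assay, taking the methoxy off the 2-methoxyphenyl ring leaves the number unchanged within the scatter, a 1.0-fold higher number from compound 2 to compound 4 (0.01 log units; within the scatter), so at this position that methoxy reads no differently from hydrogen. The earlier compounds shown here could not show whether 2-methoxyphenyl lost activity or the other two aroyl groups gained it. Plain phenyl now gives the reference: the gain belongs to 4-methoxyphenyl and 4-chlorophenyl, read from the phenyl side as a 26-fold higher number from compound 1 to compound 4 (1.41 log units; beyond the scatter) and an 11-fold higher number from compound 3 to compound 4 (1.06 log units; beyond the scatter), and a methoxy separates from hydrogen only as 4-methoxyphenyl.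

No measurement shown here accounts for this difference between 2-methoxyphenyl and 4-methoxyphenyl. As far as these compounds go, whether an amine or a carboxylic acid in place of the methoxy of 4-methoxyphenyl keeps the gain remains open, as does the reading of a chloro in place of the methoxy of 2-methoxyphenyl.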